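The source may report more compounds than this note shows. Statements on the series, on what has been measured and on what is new or still open speak of the compounds shown alone.

Among the measured compounds shown here, compound 1 `CC1(C)C(=O)N(c2ccc(SC(F)(F)F)cc2)C(=O)N1Cc1ccnc(N2CCNCC2)c1` is one of two compounds measured in a physicochemical assay for solubility, read by nephelometry; on this read-out lower numbers stand for lower solubility and higher numbers for higher solubility. In this assay compound 1 gives < 0.024 ug/mL, which is a limit of the assay rather than a number (the limit of < 0.024 ug/mL in this assay, at which 1 of the 2 values shown sits). Compound 2 `CC1(C)C(=O)N(c2ccc(SC(F)(F)F)cc2)C(=O)N1Cc1ccnc(F)c1` gives 0.032 ug/mL in this assay. For the measured compounds named here, the only measured step, an at least 1.3-fold higher number from compound 1 to compound 2 (0.12 log units; that floor lies within the scatter), lies within the scatter, so for compound 3 no step beyond the scatter is expected. Compound 3 `CC1(C)C(=O)N(c2ccc(SC(F)(F)F)cc2)C(=O)N1Cc1ccnc(NCc2ccccc2)c1` differs from compound 1 by benzylamino in place of piperazin-1-yl on an aromatic carbon. Compound 3 is therefore expected to give about 0.025 ug/mL, within 0.01 ug/mL to 0.08 ug/mL. That estimate means an expected step of an at least 1.0-fold higher number from compound 1 to compound 3 (0.01 log units; that floor lies within the scatter).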

Compound 3, solubility: < 0.026 ug/mL
Compound 3 gave a limit, no number; the forecaster's own chance of this, stated with the estimate: 50%; the middle value does not contradict the limit.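

In this assay compound 3, with benzylamino on the aromatic carbon next to the ring nitrogen, gives only a limit of the assay, not a number: the limit of < 0.026 ug/mL in this assay, at which 1 of the 3 values shown sits.

Compound 1 also gives a limit, so the step between compound 1 and compound 3 cannot be read. Benzylamino in place of fluoro gives an at least 1.2-fold lower number from compound 2 to compound 3 (0.09 log units; that floor lies within the scatter), so no difference beyond the scatter is established.

As far as these compounds go, how far below their limits compound 1 and compound 3 really lie stays open. So does whether a carboxylic acid or a morpholine ring at this position would move the read-out beyond the scatter.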